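From compound 3 to compound 4: a cytotoxicity estimate

This account rests on a few compounds, and the source may have more. Where it says the series, first, only, none or still open, it means among the compounds named here.

Compound 1 `CC(=O)Nc1ccc(NC(=O)c2cc(Cl)ccc2O)c(Cl)c1`: "not determined" (no result reported)
Compound 2 `O=C(Nc1ccc(NCc2cccc(Br)n2)cc1Cl)c1cc(Cl)ccc1O`: 92300 nM
Compound 3 `CC(CCO)Nc1ccc(NC(=O)c2cc(Cl)ccc2O)c(Cl)c1`: 200000 nM

These compounds were tested in an ADME assay on A549 cells (Homo sapiens) for cytotoxicity, read by resazurin assay, with a stated time of 48 h; a higher number here means that more compound is tolerated, a lower number that less compound is tolerated. Among the measured compounds shown here, compound 1 has no usable result, so only two numbers can be compared. Compound 3 is the higher of the two at 200000 nM, meaning that more of it is tolerated than of compound 2.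

The next compound is compound 4 `O=C(Nc1ccc(N(CCCO)CCCO)cc1Cl)c1cc(Cl)ccc1O`, which has not yet been measured. It carries bis(3-hydroxypropyl)amino in place of the (3-hydroxy-1-methylpropyl)amino of compound 3, on an aromatic carbon, meta to a chloro group: bis(3-hydroxypropyl)amino in place of (3-hydroxy-1-methylpropyl)amino on an aromatic carbon.

For the measured compounds named here, only one measured step bears on this change. It is a 2.2-fold higher number from compound 2 to compound 3 (0.34 log units; beyond the scatter), and it also concerns a group on a nitrogen on an aromatic ring. That step was modest, but it swapped a ring-bearing group for an open chain. The new change swaps one open chain for a larger group with no ring, so a step of similar size or smaller seems likely. With a single step as evidence, no direction can be favoured firmly, and no step beyond the scatter is expected in this assay. The estimated step is a 1.3-fold lower number from compound 3 to compound 4 (0.10 log units; within the scatter). For compound 4 the expected value is 160000 nM, with an estimated range of 70000 nM to 350000 nM.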

Compound 4, half-maximal cytotoxic concentration: 114000 nM
For compound 4 the middle estimate is 1.4-fold (0.15 log units) above the measured one; the measured number falls inside the stated range.
By their numbers in this assay, from the lowest: compounds 2, 4 and 3 (each within the scatter of the next, the first and the last beyond it).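

In this assay, enlarging the group on this aromatic carbon from (3-hydroxy-1-methylpropyl)amino, with 6 heavy atoms, to bis(3-hydroxypropyl)amino, with 9, gives a 1.8-fold lower number from compound 3 to compound 4 (0.24 log units; within the scatter) and so leaves the read-out without a clear change. The same open-chain group set against the ring-bearing ((6-bromopyridin-2-yl)methyl)amino gives a 1.2-fold higher number from compound 2 to compound 4 (0.09 log units; within the scatter), which means compound 4 goes against the idea, suggested by the earlier pair alone, that any open chain here clearly gives a higher number than that ring-bearing group. No measurement shown here offers an explanation for how these three compounds fall.

The compounds shown all keep a hydroxyl at the end of their open chains, so it remains open whether a chain ending in a carboxylic acid or an amine would stay within the same narrow band. As far as these compounds go, it is also open whether a longer chain, or a morpholine ring attached through its nitrogen, would separate clearly from compound 3 or compound 4 in this assay.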